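Carbonyl substituent variation, compound 2 to compound 3

The source may hold more compounds than are shown below. What is called first, only, known or untested is meant among the compounds shown, and "the series" means these compounds.

Measured so far:
compound 1, `Cc1nc(S(C)(=O)=O)ccc1Oc1ncnc(OC2CCN(C(=O)OC3COC3)CC2)c1F`, 66%
compound 2, `Cc1nc(S(C)(=O)=O)ccc1Oc1ncnc(OC2CCN(C(=O)SC3CC3)CC2)c1F`, 80%

For the measured compounds named here, in a functional assay on isolated protein for inhibition of Glucose-dependent insulinotropic receptor (Rattus norvegicus), read by HTRF and cAMP accumulation (on this read-out higher numbers stand for larger maximal responses and lower numbers for smaller maximal responses), compound 2 gives 80%, the highest of the two numbers so far. Going by the values given here, compound 1 gives 66%, and the single measured step, a number 14 percentage points higher from compound 1 to compound 2 (beyond the scatter), places compound 1 beyond the scatter below compound 2.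

Compound 3, `Cc1nc(S(C)(=O)=O)ccc1Oc1ncnc(OC2CCN(C(=O)C(F)(F)F)CC2)c1F`, is not yet measured. Its change from compound 2 is a group of 4 heavy atoms (1 carbon, 3 fluorine; no ring) in place of a group of 4 heavy atoms (3 carbon, 1 sulfur; one three-membered non-aromatic ring of carbon only), on a carbonyl carbon

Among the compounds with values here, the only measured step, a number 14 percentage points higher from compound 1 to compound 2 (beyond the scatter), also sits on the same carbonyl carbon, but it exchanges one ring-containing group for another ring-containing group; neither of those is trifluoromethyl, so it gives no direction for the present change. What it does show is that a change at this carbonyl carbon can move the maximal response by a modest amount beyond the scatter. Within the data shown here, with no step bearing directly on a trifluoromethyl group, the expectation is no step beyond the scatter, with a wide range in either direction. Compound 3 is therefore expected at 75% (range 55% to 92%). The expected step this implies, a number 5 percentage points lower from compound 2 to compound 3 (within the scatter), lies within the scatter.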

Compound 3, largest response reached (reported as efficacy), in percent of the reference or control that the assay uses: 76%
The estimate for compound 3 lay 1 percentage points below the measured number; the range from low to high includes it.
By their numbers in this assay, from the lowest: compounds 1, 3 and 2 (each within the scatter of the next, the first and the last beyond it).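

In this assay, trifluoromethyl on the carbonyl carbon gives a number 4 percentage points lower from compound 2 to compound 3 (within the scatter) and so stands level with the sulfur-linked group of compound 2; a three-membered ring and a sulfur atom are therefore not required at this position for a response of this size, since compound 3 has neither. Against the (oxetan-3-yl)oxy group, the same trifluoromethyl gives a number 10 percentage points higher from compound 1 to compound 3 (within the scatter) and thus places compound 3 within the scatter of both compound 1 and compound 2, even though those two lie beyond the scatter of each other; this position therefore shows only a modest spread across three quite different groups, and compound 3 does not settle on either side of it. No measurement in hand accounts for these numbers.

Still open, from the compounds shown here alone, is whether an amine or a longer alkyl chain on this carbonyl carbon would leave the response inside this narrow band or carry it clearly beyond the scatter of compound 2. Also open, going by these compounds, is whether a carboxylic acid at the same place would lower the response clearly below that of compound 1.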